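Capping the Hydroxyl on the Side Chain of Compound 3

A few compounds are considered here, and "the series" means these few. Any claim that something is new, unique, unknown or untested is made for them only; others in the source may bear on it.

Compound 1, `O=c1c(-c2ccc(F)cc2)c[nH]c2ccnc(Nc3ccc(Oc4ccnc5cc(OCCO)ccc45)c(F)c3)c12`: 5500 nM
Compound 2, `O=c1c(-c2ccc(F)cc2)c[nH]c2ccnc(Nc3ccc(Oc4ccnc5cc(O)ccc45)c(F)c3)c12`: 5900 nM
Compound 3, `CC(O)COc1ccc2c(Oc3ccc(Nc4nccc5[nH]cc(-c6ccc(F)cc6)c(=O)c45)cc3F)ccnc2c1`: 3900 nM

All three compounds were tested in a functional assay on HT-29 cells (Homo sapiens) for antiproliferative activity, read by MTT assay, with a stated time of 72 h; on this read-out lower numbers stand for stronger inhibition and higher numbers for weaker inhibition. Compound 3 gives the lowest of the three numbers, yet the steps of a 1.4-fold lower number from compound 1 to compound 3 (0.15 log units; within the scatter) and a 1.5-fold lower number from compound 2 to compound 3 (0.18 log units; within the scatter) both fall within the scatter, so the three compounds cannot be told apart on these numbers.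

Compound 4, `COC(C)(C)COc1ccc2c(Oc3ccc(Nc4nccc5[nH]cc(-c6ccc(F)cc6)c(=O)c45)cc3F)ccnc2c1`, differs from compound 3 in one place: 1-methoxy-1-methylethyl in place of 1-hydroxyethyl on a saturated chain carbon bound to an oxygen on an aromatic ring. The closest measured step is a 1.4-fold lower number from compound 1 to compound 3 (0.15 log units; within the scatter), which adds a methyl on a saturated chain carbon bound to an oxygen on a saturated carbon and a saturated chain carbon and stays within the scatter. The other two steps, a 1.1-fold higher number from compound 1 to compound 2 (0.03 log units; within the scatter) and a 1.5-fold lower number from compound 2 to compound 3 (0.18 log units; within the scatter), exchange the whole group on the oxygen on the aromatic ring and also stay within the scatter. Going by the values given here, no measured step here tests the loss of the hydrogen-bond donor or the entry of the second methyl. Given that every change in this region so far has stayed within the scatter, the step of a 1.3-fold higher number from compound 3 to compound 4 (0.11 log units; within the scatter) is expected to do the same. Compound 4 is therefore estimated at 5000 nM, with a range from 2500 nM to 10000 nM.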

Compound 4, half-maximal inhibitory concentration: 4800 nM
Estimate against measurement, compound 4: 1.0-fold (0.02 log units) above; the measured number falls inside the stated range.
By their numbers in this assay, from the lowest: compounds 3, 4, 1 and 2 (each within the scatter of the next).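

In this assay the exchange of 1-hydroxyethyl for 1-methoxy-1-methylethyl goes from a group with 1 hydrogen-bond donor and 3 heavy atoms to one with 0 hydrogen-bond donors and 5 heavy atoms, yet the step stays within the scatter (a 1.2-fold higher number from compound 3 to compound 4 (0.09 log units; within the scatter)). Going by these compounds alone, this is the first direct test of that exchange on a saturated chain carbon bound to an oxygen on an aromatic ring, and the two other new steps also stay within the scatter, one replacing hydrogen with 2-methoxy-2-methylpropyl on the oxygen (a 1.2-fold lower number from compound 2 to compound 4 (0.09 log units; within the scatter)) and the other replacing hydroxymethyl with 1-methoxy-1-methylethyl (a 1.1-fold lower number from compound 1 to compound 4 (0.06 log units; within the scatter)). Nothing available here accounts for this lack of separation among the compounds.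

The compounds shown leave open whether a side chain ending in an amine or a carboxylic acid, or a longer chain, would move the number beyond the scatter. Within the data shown here, they also leave open whether the same tolerance for the side chain would hold on a core other than the one these compounds share.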